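A few compounds are considered here, and "the series" means these few. Any claim that something is new, unique, unknown or untested is made for them only; others in the source may bear on it.

Compound 1 `COc1ccc(C(CC(=O)O)Cc2nc(CCCc3ccc4c(n3)NCCC4)no2)cn1` and compound 2 `O=C(O)CC(Cc1nc(CCCc2ccc3c(n2)NCCC3)no1)c1ccc2c(c1)OCC2` share one core and differ only in the group on the saturated chain carbon bound to two saturated chain carbons. In an in vivo ADME assay on the whole organism for metabolic stability, with Rattus norvegicus as the target, at a dose of 5 mg/kg by the intravenous route (a lower number here means that the compound disappears faster, a higher number that the compound lasts longer), compound 1 gives 1.1 h and compound 2 gives 1.2 h, the top of the two numbers, although a 1.1-fold higher number from compound 1 to compound 2 (0.04 log units; within the scatter) sits within the scatter. Compound 3 `O=C(O)CC(Cc1nc(CCCc2ccc3c(n2)NCCC3)no1)c1cnc2ccccc2c1` carries a group of 10 heavy atoms (9 carbon, 1 nitrogen; one six-membered aromatic ring of carbon only, one six-membered aromatic ring with 1 hetero atom) in place of a group of 9 heavy atoms (8 carbon, 1 oxygen; one five-membered non-aromatic ring with 1 hetero atom, one six-membered aromatic ring of carbon only), on a saturated chain carbon bound to two saturated chain carbons. Going by the values given here, the only step bearing on this change, from compound 1 to compound 2, was flat, so the expected step is no change at the digits printed from compound 2 to compound 3 (within the scatter), nothing beyond the scatter. Compound 3 is therefore estimated at 1.2 h, with a range of 0.7 h to 2 h.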

Compound 3, half-life: 1.1 h
For compound 3 the middle estimate is 1.1-fold (0.04 log units) above the measured one; the range from low to high includes it.
By their numbers in this assay, from the lowest: compounds 1, 3 and 2 (each within the scatter of the next).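

At the saturated chain carbon bound to two saturated chain carbons, quinolin-3-yl adds a third aryl group to the comparison in this assay: a 1.1-fold lower number from compound 2 to compound 3 (0.04 log units; within the scatter) and no change at the digits printed from compound 1 to compound 3 (within the scatter). The half-life therefore does not separate the three groups at this position, even with the second aromatic ring carrying a ring nitrogen. Nothing available explains this flat result.

Going by these compounds, whether a cyclohexyl group or a primary amine at this carbon would move the half-life beyond the scatter remains open. So does the effect of replacing the carboxylic acid with an amide.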